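The source may report more compounds than this note shows. Statements on the series, on what has been measured and on what is new or still open speak of the compounds shown alone.

Series notes. In a functional assay on RKO cells (Homo sapiens) for cytotoxicity, read by MTT assay, with a stated time of 48 h (on this read-out lower numbers stand for stronger inhibition and higher numbers for weaker inhibition), compound 1 `CN(C)CCNc1ccnc2cc(OCc3ccc(F)cc3)ccc12` gives 580 nM. Going by the values given here, compound 2 `CN(C)CCCNc1ccnc2cc(OCc3ccc(F)cc3)ccc12` gives 1230 nM, the highest of the two numbers so far; the only measured step, a 2.1-fold higher number from compound 1 to compound 2 (0.33 log units; beyond the scatter), concerns the chain on the aromatic nitrogen. Compound 3 `C=CCOc1ccc2c(NCCCN(C)C)ccnc2c1` is not yet measured. It differs from compound 2 at the other end of the molecule: vinyl in place of 4-fluorophenyl on a saturated chain carbon bound to an oxygen on an aromatic ring. Among the compounds with values here, no measured step touches this position, so the change from compound 2 to compound 3 has no precedent here and no direction can be expected beyond the scatter. The step is therefore estimated as a 1.2-fold higher number from compound 2 to compound 3 (0.09 log units; within the scatter), with wide uncertainty. Compound 3 is expected near 1500 nM, within 500 nM to 5000 nM.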

Compound 3, half-maximal inhibitory concentration: 3560 nM
Compound 3: the middle estimate sits 2.4-fold (0.38 log units) below what was measured; the range from low to high includes it.
By their numbers in this assay, from the lowest: compound 1; then compound 2; then compound 3.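

Going by these compounds alone, the end of the molecule bound through the ether oxygen responds to change: in this assay, replacing 4-fluorobenzyl with allyl gives a 2.9-fold higher number from compound 2 to compound 3 (0.46 log units; beyond the scatter), the first measured step at this position. This single change removes the six-membered aromatic ring and the fluorine together, so their contributions cannot be separated. Nothing available explains the step.

Going by these compounds, whether plain benzyl on the same oxygen would stay near compound 2 remains open, as does the effect of a saturated propyl group in place of allyl. Also open, on these data alone, is whether the step holds on the shorter amine chain of compound 1.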